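From 2-chlorobenzyl to 3-bromobenzyl in a weak series

The source may hold more compounds than are shown below. What is called first, only, known or untested is meant among the compounds shown, and "the series" means these compounds.

In a functional assay on HeLa cells (Homo sapiens) for antiproliferative activity, read by MTT assay, with a stated time of 48 h (a lower number here means a stronger inhibitor, a higher number a weaker inhibitor), compound 1 `Brc1ccc(CSc2nnc(-c3cnccn3)o2)cc1` gives 21600 nM, the only numerical result so far. Compound 2 `Fc1cccc(F)c1CSc1nnc(-c2cnccn2)o1` reads > 50000 nM, which is a limit. Compound 3 `Clc1ccccc1CSc1nnc(-c2cnccn2)n1-c1ccccc1` reads > 50000 nM, which is also a limit. That places it at the limit of > 50000 nM in this assay, at which 2 of the 3 values shown sit.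

Compound 4 `Brc1cccc(CSc2nnc(-c3cnccn3)n2-c2ccccc2)c1` differs from compound 3 by 3-bromophenyl in place of 2-chlorophenyl on a saturated chain carbon bound to a sulfur. No measured step sizes this change in this assay. Compound 1, at 21600 nM, also carries bromine on its benzyl group, so a small move toward stronger inhibition is expected, estimated as an at least 1.3-fold lower number from compound 3 to compound 4 (0.11 log units; that floor lies within the scatter). Compound 4 is expected at 38000 nM, with an estimated range of 15000 nM to 70000 nM.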

Compound 4, half-maximal inhibitory concentration: 9580 nM
Estimate against measurement, compound 4: 4.0-fold (0.60 log units) above; measured number below the stated range.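

In this assay, within the data shown here, the change to 3-bromophenyl on a saturated chain carbon bound to a sulfur gives an at least 5.2-fold lower number from compound 3 to compound 4 (0.71 log units; beyond the scatter) and is the first readable effect at this position. That size is only a floor, because compound 3 stands at a limit of the assay: the limit of > 50000 nM in this assay, at which 2 of the 4 values shown sit.

This one step changes both the halogen and its place on the ring, and the compounds shown cannot separate the two. Also open, as far as these compounds go, is whether a methoxy group or an amine in place of the bromine would keep the gain.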